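Methyl on the Sulfonyl Ring: What Compound 4 Should Show

A few compounds are considered here, and "the series" means these few. Any claim that something is new, unique, unknown or untested is made for them only; others in the source may bear on it.

Of the compounds shown here, three share a core and have been measured in a functional assay on the whole organism (strain Sprague-Dawley) for inhibition, with Rattus norvegicus as the target, read by paw edema, with stated times of 30 min and 3 h, at a dose of 80 mg/kg by the oral route; on this read-out lower numbers stand for less inhibition and higher numbers for more inhibition at the one dose given (going by the name of the read-out). Compound 1 `O=c1c2ccccc2nc(CO[N+](=O)[O-])n1NS(=O)(=O)c1ccccc1` gives 34%. Compound 2 `Cc1nc2ccccc2c(=O)n1NS(=O)(=O)c1ccccc1` gives 47.8%, and compound 3 `Cc1nc2ccccc2c(=O)n1NC(=S)Nc1ccccc1` gives 61.9%. Compound 2 thus stands second highest of the three, with compound 1 below it and compound 3 above it, both beyond the scatter. For the measured compounds named here, the one single-point step between measured compounds, hydrogen in place of nitrooxy on a saturated chain carbon bound to an aromatic carbon, gave a number 13.8 percentage points higher from compound 1 to compound 2 (beyond the scatter).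

Compound 4 `Cc1ccc(S(=O)(=O)Nn2c(C)nc3ccccc3c2=O)cc1` differs from compound 2 in a different place: methyl in place of hydrogen on an aromatic carbon. Going by the values given here, no measured step touches the ring carrying the sulfonyl group, so the measured step from compound 1 to compound 2 does not bear on this change, and nothing among the measured compounds points in either direction. The step from compound 2 to compound 4 is therefore expected to be a number 0.2 percentage points higher from compound 2 to compound 4 (within the scatter), within the scatter. Compound 4 is estimated at 48%, with a range from 36% to 60%.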

Compound 4, a percentage reported as inhibition, in the whole organism at one dose (the size of the read-out at that dose, not a potency): 51.9%
Estimate against measurement, compound 4: 3.9 percentage points below; measured number inside the range.
By their numbers in this assay, from the lowest: compound 1; then compounds 2, 4 and 3 (each within the scatter of the next, the first and the last beyond it).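

In this assay the change from phenyl to 4-methylphenyl, on an aromatic carbon para to a large group, gives a number 4.1 percentage points higher from compound 2 to compound 4 (within the scatter) at the one dose given. For the compounds shown here, this is the first reading on the ring carrying the sulfonyl group, and unlike the earlier change on the saturated chain carbon, which gave a number 13.8 percentage points higher from compound 1 to compound 2 (beyond the scatter) in the same read-out, it stays within the scatter. Nothing in the data shown offers a reason for the size of this step.

Methyl is the only group on that ring among the compounds shown, so whether a methoxy group, an amine or a carboxylic acid at the same place would move the inhibition remains open. Also open, as far as these compounds go, is whether the methyl step would read the same on the core of compound 1, which carries the nitrooxy group.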